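Swapping Chloro for Nitro on a Benzylsulfanyl Side Chain

The source may report more compounds than this note shows. Statements on the series, on what has been measured and on what is new or still open speak of the compounds shown alone.

Of the compounds shown here, three sharing one core have been tested in a functional assay on MGC-803 cells (Homo sapiens) for inhibition, read by MTT assay, with a stated time of 72 h; on this read-out higher numbers stand for weaker inhibition and lower numbers for stronger inhibition. Compound 1 `Cc1cc(N2CC[C@@H](C)[C@@H](N(C)c3ncnc4[nH]ccc34)C2)n2nc(SCc3ccc(Cl)cc3)nc2n1` carries a (4-chlorobenzyl)sulfanyl group on an aromatic carbon of the core and gives 16000 nM. Compound 2 `Cc1cc(N2CC[C@@H](C)[C@@H](N(C)c3ncnc4[nH]ccc34)C2)n2ncnc2n1` has hydrogen at that position and gives 4350 nM, while compound 3 `C=CCSc1nc2nc(C)cc(N3CC[C@@H](C)[C@@H](N(C)c4ncnc5[nH]ccc45)C3)n2n1` has an allylsulfanyl group there and gives 32600 nM. Among these three numbers compound 1 stands second highest: the step of a 3.7-fold lower number from compound 1 to compound 2 (0.57 log units; beyond the scatter) shows that removing the whole side chain gives a lower number, and the step of a 2.0-fold higher number from compound 1 to compound 3 (0.31 log units; beyond the scatter) shows that vinyl in place of 4-chlorophenyl gives a higher one.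

Compound 4 `Cc1cc(N2CC[C@@H](C)[C@@H](N(C)c3ncnc4[nH]ccc34)C2)n2nc(SCc3ccc([N+](=O)[O-])cc3)nc2n1` differs from compound 1 by nitro in place of chloro on an aromatic carbon. Going by the values given here, no measured step touches only the group on this six-membered aromatic ring; the nearest comparison, the step from compound 1 to compound 3, replaces the entire 4-chlorophenyl and was modest. With the sulfur-bound chain and ring kept intact, the expectation for this assay is a change no larger than the scatter, with slight uncertainty in either direction. Compound 4 is therefore estimated at 16000 nM, with a range from 6000 nM to 40000 nM, so that the expected step of no change at the digits printed from compound 1 to compound 4 (within the scatter) is small.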

Compound 4, half-maximal inhibitory concentration: 27000 nM
Compound 4: the middle estimate sits 1.7-fold (0.23 log units) below what was measured, within the range that was stated.
By their numbers in this assay, from the lowest: compound 2; then compounds 1, 4 and 3 (each within the scatter of the next, the first and the last beyond it).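

In this assay, going by these compounds alone, the step of a 1.7-fold higher number from compound 1 to compound 4 (0.23 log units; within the scatter) is the first to change only the group on the six-membered aromatic ring, and it shows that nitro in place of chloro at this spot, para to a large group, cannot be told apart from no change. The step of a 1.2-fold lower number from compound 3 to compound 4 (0.08 log units; within the scatter) is also within the scatter, so the 4-nitrobenzyl and allyl groups on the sulfur cannot be separated here, although compound 1 and compound 3 do differ by slightly more than the scatter. The step of a 6.2-fold higher number from compound 2 to compound 4 (0.79 log units; beyond the scatter) adds a third side chain on sulfur that gives a higher number than hydrogen on that aromatic carbon of the core, and none of the four compounds goes against this pattern.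

No measurement shown here gives a reason for any of these numbers. Still open, on these data alone, is whether an amine or a carboxylic acid in place of the nitro would leave the number within the scatter, and whether a small methylsulfanyl group on the core would give a number closer to that of compound 2 or to those of the larger side chains.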